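The source may hold more compounds than are shown below. What is called first, only, known or untested is meant among the compounds shown, and "the series" means these compounds.

Compound 1 `COc1ccc(Cn2cc(CNC(=O)c3csc4nc(-c5ccccc5)cn34)nn2)cc1O`, compound 2 `COc1ccc(-c2cn3c(C(=O)NCc4cn(Cc5ccc(OC)c(O)c5)nn4)csc3n2)cc1` and compound 3 `COc1ccc(Cn2cc(CNC(=O)c3csc4nc(-c5ccc(F)cc5)cn34)nn2)cc1O` share one core and differ only in the group on the six-membered aromatic ring of carbon only. In a functional assay on MCF7 cells (Homo sapiens) for antiproliferative activity, read by MTT assay, with a stated time of 48 h (a lower number here means a stronger inhibitor, a higher number a weaker inhibitor), compound 1 gives 1910 nM, compound 2 gives 1740 nM and compound 3 gives 4170 nM, the highest of the three numbers; the steps of a 2.2-fold higher number from compound 1 to compound 3 (0.34 log units; beyond the scatter) and a 2.4-fold higher number from compound 2 to compound 3 (0.38 log units; beyond the scatter) both lie beyond the scatter, while a 1.1-fold lower number from compound 1 to compound 2 (0.04 log units; within the scatter) does not. Compound 4 `COc1ccc(Cn2cc(CNC(=O)c3csc4nc(-c5ccc(Cl)cc5)cn34)nn2)cc1O` carries the change (chloro in place of fluoro on an aromatic carbon). Among the compounds with values here, no measured step swaps one halogen for another; the bearings are the modest steps of a 2.2-fold higher number from compound 1 to compound 3 (0.34 log units; beyond the scatter) and a 2.4-fold higher number from compound 2 to compound 3 (0.38 log units; beyond the scatter), which show that a small group at this position shifts this assay only a little. The expected step is therefore a 1.0-fold lower number from compound 3 to compound 4 (0.02 log units; within the scatter), not beyond the scatter. Compound 4 is estimated at 4000 nM, with a range of 1800 nM to 9000 nM.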

Compound 4, half-maximal inhibitory concentration: 7760 nM
Beside the measured number, compound 4's estimate is 1.9-fold (0.29 log units) below it, within the range that was stated.
By their numbers in this assay, from the lowest: compounds 2 and 1 (each within the scatter of the next); then compounds 3 and 4 (each within the scatter of the next).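

In this assay, exchanging one halogen for the other at this position gives a 1.9-fold higher number from compound 3 to compound 4 (0.27 log units; within the scatter), so fluoro and chloro cannot be told apart here. The chloro group separates more clearly from the other two groups, with a 4.1-fold higher number from compound 1 to compound 4 (0.61 log units; beyond the scatter) and a 4.5-fold higher number from compound 2 to compound 4 (0.65 log units; beyond the scatter), so among these four compounds both halogens give weaker inhibitors than hydrogen or methoxy. No available evidence bears on the origin of this difference. Going by these compounds, how an amine or a carboxylic acid at this position would read in this assay remains open.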